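Thiophene in place of the methylphenyl ring

This account rests on a few compounds, and the source may have more. Where it says the series, first, only, none or still open, it means among the compounds named here.

Compound 1 `CC/C(=C(\c1ccc2[nH]ncc2c1)c1ccc(/C=C/C(=O)O)cc1C)c1ccccc1`: 36 nM
Compound 2 `CC/C(=C(/c1csc(/C=C/C(=O)O)c1)c1ccc2[nH]ncc2c1)c1ccccc1`: 2900 nM
Compound 3 `CC/C(=C(/c1ccc(/C=C/C(=O)O)cc1)c1ccc2[nH]ncc2c1)c1ccccc1C`: 4 nM

Three compounds built on a shared core were tested in a functional assay on MCF7 cells (Homo sapiens) for cytotoxicity, read by CellTiter-Glo, with a stated time of 5 days; on this read-out lower numbers stand for stronger inhibition and higher numbers for weaker inhibition. Compound 3 gives 4 nM, the lowest of the three numbers. Compound 1 gives 36 nM, a higher number that lies beyond the scatter, and compound 2 gives 2900 nM, higher still and far beyond it. No two of these compounds differ in only one place, so none of the gaps between them can be tied to a single structural change.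

Compound 4 `CC/C(=C(/c1ccc(/C=C/C(=O)O)cc1)c1ccc2[nH]ncc2c1)c1cscc1C` differs from compound 3 in one place: 4-methylthiophen-3-yl in place of 2-methylphenyl on a double-bonded chain carbon bound to a double-bonded chain carbon and a saturated chain carbon. Compound 2 also carries a five-membered ring and gives the highest number of the set, but it differs from compound 3 in more than one place, so that pair says nothing about the exchange made here. Among the compounds with values here, with no measured step to lean on, the expected step from compound 3 to compound 4 in this assay is a moderate rise, a 3.0-fold higher number from compound 3 to compound 4 (0.48 log units; beyond the scatter), beyond the scatter but well short of the gap to compound 2. Compound 4 is therefore estimated at 12 nM, with a likely range from 3 nM to 50 nM.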

Compound 4, half-maximal inhibitory concentration: 2 nM
The estimate for compound 4 lay 6.0-fold (0.78 log units) above the measured number; measured number below the stated range.
By their numbers in this assay, from the lowest: compounds 4 and 3 (each within the scatter of the next); then compound 1; then compound 2.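

In this assay, 4-methylthiophen-3-yl in place of 2-methylphenyl on a double-bonded chain carbon bound to a double-bonded chain carbon and a saturated chain carbon gives a 2.0-fold lower number from compound 3 to compound 4 (0.30 log units; within the scatter), so this read-out does not separate the two compounds. Within the data shown here, this is the first step in the set that can be tied to a single structural change, and it shows that, with the rest of compound 3 held constant, a five-membered aromatic ring with 1 hetero atom can take the place of a six-membered aromatic ring of carbon only while the number stays within the scatter. No measurement of any property bears on this result, and the data offer no explanation for it.

The compounds shown leave open whether the methyl group on the thiophene matters at this position, as they do not show how a thiophen-3-yl without it, or with a chlorine atom in its place, would read. They also leave open whether a pyridine ring at the same place would stay within the scatter of compound 4.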